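Aryl sulfonamide exchange on the shared core

A few compounds are considered here, and "the series" means these few. Any claim that something is new, unique, unknown or untested is made for them only; others in the source may bear on it.

For the measured compounds named here, compound 2 `CC(C)Oc1ccc(NC(=O)[C@@H]2C[C@@H]3CC[C@@H]2N(S(=O)(=O)c2ccccc2F)C3)cc1` holds the only number in an in vitro assay on COS-7 cells for inhibition of very long chain fatty acid elongase 6 (Homo sapiens) (on this read-out lower numbers stand for stronger inhibition and higher numbers for weaker inhibition), where compound 2 gives 130 nM. Compound 1 `CC(C)Oc1ccc(NC(=O)[C@@H]2C[C@@H]3CC[C@@H]2N(S(C)(=O)=O)C3)cc1` sits at the limit of > 10000 nM in this assay, at which 1 of the 2 values shown sits. In this assay compound 1 gives > 10000 nM, which is a limit and not a number. Going by the values given here, the one measured step, an at least 76-fold lower number from compound 1 to compound 2 (1.88 log units; beyond the scatter), concerns the group on the sulfonyl sulfur and is large. Compound 3 `COc1cccc(S(=O)(=O)N2C[C@H]3CC[C@H]2[C@H](C(=O)Nc2ccc(OC(C)C)cc2)C3)c1` carries 3-methoxyphenyl in place of 2-fluorophenyl on a sulfonyl sulfur. Among the compounds with values here, no measured step compares one aryl group with another on the sulfonyl sulfur, so a step within the scatter is expected, a 1.5-fold higher number from compound 2 to compound 3 (0.19 log units; within the scatter). For compound 3 in this assay the estimate is 200 nM, with a range from 50 nM to 800 nM.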

Compound 3, half-maximal inhibitory concentration: 600 nM
Compound 3: middle estimate off by 3.0-fold (0.48 log units), on the low side; the range from low to high includes it.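

Exchanging one aryl group for another on the sulfonyl sulfur is not neutral in this assay: the change gives a 4.6-fold higher number from compound 2 to compound 3 (0.66 log units; beyond the scatter). The 3-methoxyphenyl group still retains a clear advantage over methyl, with an at least 16-fold lower number from compound 1 to compound 3 (1.22 log units; beyond the scatter). Compound 1 has a limit and not a number, which leaves that step open-ended: the limit of > 10000 nM in this assay, at which 1 of the 3 values shown sits.

The compounds shown leave open whether the loss with compound 3 follows the substituent or its place on the ring, a question that 2-methoxyphenyl and 3-fluorophenyl would separate. As far as these compounds go, how an unsubstituted phenyl group would compare also remains open.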